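The compounds below may be only part of what the source reports. "The series", "measured", "known", "first", "only" and "open" are said of these compounds alone.

- compound 1 `O=C1/C(=C\c2ccccc2)S/C(=N/c2ccccc2)N1Cc1ccncc1`: 25200 nM
- compound 2 `COc1ccc(/C=C2/S/C(=N/c3ccccc3)N(Cc3ccncc3)C2=O)cc1`: 19100 nM
- compound 3 `O=C1/C(=C\c2ccc(Cl)cc2)S/C(=N/c2ccccc2)N1Cc1ccncc1`: 28800 nM

All three values come from a functional assay on HepG2 cells (Homo sapiens) for cytotoxicity, read by MTT assay, with a stated time of 48 h; on this read-out higher numbers stand for weaker inhibition and lower numbers for stronger inhibition. Compound 3 cannot be told apart from the other two, with a 1.1-fold higher number from compound 1 to compound 3 (0.06 log units; within the scatter) and a 1.5-fold higher number from compound 2 to compound 3 (0.18 log units; within the scatter).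

The next compound, compound 4 `COc1ccc(/C=C2/S/C(=N/c3ccccc3)N(Cc3ccncc3)C2=O)cc1OC`, keeps the shared core and differs from compound 3 in one group: 3,4-dimethoxyphenyl in place of 4-chlorophenyl on a double-bonded chain carbon bound to a double-bonded ring carbon. Here 3,4-dimethoxyphenyl stands in place of 4-chlorophenyl on a double-bonded chain carbon bound to a double-bonded ring carbon.

The closest evidence is the exchange of chloro and methoxy, which gave a 1.5-fold higher number from compound 2 to compound 3 (0.18 log units; within the scatter). Methoxy in place of hydrogen gave a 1.3-fold lower number from compound 1 to compound 2 (0.12 log units; within the scatter). All of these steps stay within the scatter. Among the compounds with values here, no measured compound carries a 3,4-dimethoxyphenyl group, so this exact change remains untested. In this assay, no step beyond the scatter is therefore expected. The expected step is a 1.4-fold lower number from compound 3 to compound 4 (0.14 log units; within the scatter). The estimated value for compound 4 is 21000 nM, within an expected range of 10000 nM to 42000 nM.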

Compound 4, half-maximal inhibitory concentration: 28900 nM
Beside the measured number, compound 4's estimate is 1.4-fold (0.14 log units) below it; the measured number falls inside the stated range.
By their numbers in this assay, from the lowest: compounds 2, 1, 3 and 4 (each within the scatter of the next).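

In this assay, the step with a 1.0-fold higher number from compound 3 to compound 4 (0.00 log units; within the scatter) shows that 3,4-dimethoxyphenyl and 4-chlorophenyl cannot be told apart at this double-bonded chain carbon, although the entering group has more heavy atoms and brings hydrogen-bond acceptors. A further methoxy on the aromatic ring gives a 1.5-fold higher number from compound 2 to compound 4 (0.18 log units; within the scatter) and the full change from phenyl gives a 1.1-fold higher number from compound 1 to compound 4 (0.06 log units; within the scatter), so a ring carrying two methoxy groups at this position also leaves the number within the scatter of the simpler compounds. Nothing available here offers an explanation for this flat result.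

All the groups shown at this position are phenyl rings that are bare or carry chloro or methoxy. As far as these compounds go, whether an amine, a carboxylic acid or a longer chain on that ring would produce a step beyond the scatter remains open.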